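Trifluoromethyl to trifluoromethoxy on a shared core

The compounds below may be only part of what the source reports. "The series", "measured", "known", "first", "only" and "open" are said of these compounds alone.

All values below come from a toxicity assay on Vero cells (Chlorocebus sabaeus) for cytotoxicity; on this read-out higher numbers stand for lower toxicity in this test and lower numbers for higher toxicity in this test.

Compound 1: `COc1nc(C(C)(C)C)ccc1[C@@H](c1ccccc1)[C@@](O)(CCN(C)C)c1cccc2ccccc12` — 27.6 ug/mL
Compound 2: `COc1nc(-c2cccc(Cl)c2)ccc1[C@@H](c1ccccc1)[C@@](O)(CCN(C)C)c1cccc2ccccc12` — > 50 ug/mL, a limit
Compound 3: `COc1nc(-c2ccc(C(F)(F)F)cc2)ccc1[C@@H](c1ccccc1)[C@@](O)(CCN(C)C)c1cccc2ccccc12` — > 50 ug/mL, a limit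

Compound 3 stands at the top of the measured range: in this assay compound 3 gives > 50 ug/mL, which is a limit of the assay and not a number. Compound 2 also sits at a limit, > 50 ug/mL. This matters because of the limit of > 50 ug/mL in this assay, at which 2 of the 3 values shown sit, so only compound 1 carries a real number, 27.6 ug/mL.

Compound 4 is `COc1nc(-c2ccc(OC(F)(F)F)cc2)ccc1[C@@H](c1ccccc1)[C@@](O)(CCN(C)C)c1cccc2ccccc12`. It differs from compound 3 by trifluoromethoxy in place of trifluoromethyl on an aromatic carbon.

The measured steps give little guidance: an at least 1.8-fold higher number from compound 1 to compound 2 (0.25 log units; that floor lies within the scatter) and an at least 1.8-fold higher number from compound 1 to compound 3 (0.25 log units; that floor lies within the scatter) both exchange a tert-butyl for an aryl group, while a step that the two limits leave unreadable from compound 2 to compound 3 is unreadable. None of them exchanges a trifluoromethyl for a trifluoromethoxy.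

Compound 4 is therefore expected to sit where compound 3 does, with an estimated step of a number no higher from compound 3 to compound 4 (the limit leaves the size open). The estimate for compound 4 is 50 ug/mL, within 25 ug/mL to 100 ug/mL, most likely again reported only as a limit.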

Compound 4, half-maximal cytotoxic concentration: > 50 ug/mL
Compound 4 gave a limit, no number; the forecaster's own chance of this, stated with the estimate: 70%; the middle value lies on the limit itself.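

In this assay compound 4 gives > 50 ug/mL, which is a limit of the assay and not a number. Among the compounds shown here, the one readable step is an at least 1.8-fold higher number from compound 1 to compound 4 (0.25 log units; that floor lies within the scatter), so this is a third aryl group in place of tert-butyl that ends at the limit, though the floor of that step does not separate it from compound 1. As far as these compounds go, the steps from compound 2 and compound 3 to compound 4 cannot be read, so the size of the exchange of trifluoromethyl for trifluoromethoxy stays unknown, because the values pile up at one ceiling: the limit of > 50 ug/mL in this assay, at which 3 of the 4 values shown sit.

From the compounds shown here alone, how far compound 2, compound 3 and compound 4 truly lie from one another remains open. Also open, going by these compounds, is whether an amine or a carboxylic acid in place of the trifluoromethoxy would give a real number in this test.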